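Half-life notes on compound 1 and its hydrogen analogue

This account rests on a few compounds, and the source may have more. Where it says the series, first, only, none or still open, it means among the compounds named here.

Measured in an ADME assay for metabolic stability, in phosphate buffer, at pH 7.3; on this read-out lower numbers stand for a shorter-lived compound and higher numbers for a longer-lived compound
- compound 1 `COc1ccc2c(c1)COP(=O)(OC[C@@H]1C=C[C@H](n3cnc4c(N)ncnc43)O1)O2` gives 14.5 h
- compound 2 `Nc1ncnc2c1ncn2C1CCC(COP2(=O)OCc3ccccc3O2)O1` gives 17 h

Among the compounds with values here, compound 1 stands within the scatter of compound 2, the only other measured compound, so the two numbers cannot be told apart. Still unmeasured is compound 3 `Nc1ncnc2c1ncn2[C@H]1C=C[C@@H](COP2(=O)OCc3ccccc3O2)O1`, which differs from compound 1 as follows: hydrogen in place of methoxy on an aromatic carbon. Within the data shown here, no measured step isolates this change, so the data give no direct size for it. In this assay a step within the scatter is expected, with a slight lean towards a shorter half-life as a judgement only. The estimate puts the expected step of a 1.2-fold lower number from compound 1 to compound 3 (0.08 log units; within the scatter) inside the scatter. For compound 3 the estimated half-life is 12 h, with an expected range from 6 h to 22 h.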

Compound 3, half-life: 10.3 h
For compound 3 the middle estimate is 1.2-fold (0.07 log units) above the measured one; the measured number falls inside the stated range.
By their numbers in this assay, from the lowest: compounds 3, 1 and 2 (each within the scatter of the next).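

Hydrogen in place of methoxy on this aromatic carbon gives a 1.4-fold lower number from compound 1 to compound 3 (0.15 log units; within the scatter) in this assay and is the first direct read on this position. The methoxy group, with its two heavy atoms and one hydrogen-bond acceptor, can therefore be removed here without a step that stands clear of the scatter. Nothing available explains why this step is so small.

On these data alone, what stays open is whether other groups on this aromatic carbon, such as fluorine, an amine, a carboxylic acid or a longer alkoxy chain, would move the half-life beyond the scatter. One step also leaves open whether hydrogen in place of methoxy would read the same on the other aromatic carbons of this ring.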